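The source may hold more compounds than are shown below. What is called first, only, known or untested is meant among the compounds shown, and "the series" means these compounds.

Going by the values given here, in a functional assay on HeLa cells (Homo sapiens) for cytotoxicity, read by MTT assay, with a stated time of 48 h (a higher number here means a weaker inhibitor, a lower number a stronger inhibitor), two compounds with a shared core have numbers so far. Compound 1 `C=C1CCC[C@]2(C)CCC(c3cn(-c4ccc(I)cc4)nn3)=CC[C@@]12C` carries 4-iodophenyl on an aromatic nitrogen and gives 144000 nM as its half-maximal inhibitory concentration. Compound 2 `C=C1CCC[C@]2(C)CCC(c3cn(-c4ccccc4C(C)=O)nn3)=CC[C@@]12C` carries 2-acetylphenyl at that place and gives 55700 nM as its value, the lower of the two numbers, which makes it the stronger inhibitor of the pair.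

Compound 3 `C=C1CCC[C@]2(C)CCC(c3cn(-c4cccc(OC)c4)nn3)=CC[C@@]12C` has not been measured yet. It has 3-methoxyphenyl in place of 2-acetylphenyl on an aromatic nitrogen, counted as 3-methoxyphenyl in place of 2-acetylphenyl on an aromatic nitrogen with the rest of the structure unchanged. Among the compounds with values here, the only measured step that bears on this is a 2.6-fold lower number from compound 1 to compound 2 (0.41 log units; beyond the scatter) and it changed the group at the same place, a modest move beyond the scatter. One step between two other groups gives a size but no direction for 3-methoxyphenyl. With compound 2 at 55700 nM as the low end of just two numbers, a modest step or smaller is expected in this assay and more likely toward a higher number, possibly one within the scatter. Expressed as an estimate, the expected move is a 1.3-fold higher number from compound 2 to compound 3 (0.13 log units; within the scatter) on this reasoning. The estimated value for compound 3 is 75000 nM (expected range 30000 nM to 150000 nM).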

Compound 3, half-maximal inhibitory concentration: 27900 nM
The estimate for compound 3 lay 2.7-fold (0.43 log units) above the measured number; measured number outside the range, below it.
By their numbers in this assay, from the lowest: compounds 3 and 2 (each within the scatter of the next); then compound 1.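

Replacing 2-acetylphenyl with 3-methoxyphenyl on this aromatic nitrogen gives a 2.0-fold lower number from compound 2 to compound 3 (0.30 log units; within the scatter) in this assay, so the assay does not separate these two compounds. The acetyl group is therefore not needed to reach this level of activity, as a different group on the phenyl ring serves equally well here. The wider comparison gives a 5.2-fold lower number from compound 1 to compound 3 (0.71 log units; beyond the scatter), which shows that 4-iodophenyl now stands apart from two different groups rather than just one, although nothing measured here explains this difference.

Compound 2 and compound 3 differ both in the group on the phenyl ring and in where it sits, so the compounds shown cannot reveal which of these two changes matters, or whether either does. Going by these compounds alone, it also remains open how a plain phenyl ring would compare, and whether an amine or a carboxylic acid on that ring would move the number in either direction, so the trend across this position rests on only three aryl groups.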